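N-Methylation of the Glycinamide in Two Chromene Series

This account rests on a few compounds, and the source may have more. Where it says the series, first, only, none or still open, it means among the compounds named here.

Measured compounds:
- compound 1 `COc1ccc(C(=O)c2ccc(OC)c3c2C=CC(C)(C)O3)c(NC(=O)CN)c1`: 1050 nM
- compound 2 `CNCC(=O)Nc1cc(OC)ccc1C(=O)c1ccc(OC)c2c1C=CC(C)(C)O2`: 3460 nM
- compound 3 `C=C(c1ccc(OC)cc1NC(=O)CN)c1ccc(OC)c2c1C=CC(C)(C)O2`: 520 nM

All three were tested in a functional assay on HCT-8 cells (Homo sapiens) for antiproliferative activity, read by MTT assay, with a stated time of 48 h; a higher number here means a weaker inhibitor, a lower number a stronger inhibitor. Compound 1 gives 1050 nM, while compound 2 differs from it by methyl in place of hydrogen on an amine nitrogen and this change gave a 3.3-fold higher number from compound 1 to compound 2 (0.52 log units; beyond the scatter). Compound 3 has the lowest number of the three in this assay; the difference between its core and that of compound 1 is not broken down here. Compound 4 `C=C(c1ccc(OC)cc1NC(=O)CNC)c1ccc(OC)c2c1C=CC(C)(C)O2` has not been measured. It differs from compound 3 by methyl in place of hydrogen on an amine nitrogen, the same change as that between compound 1 and compound 2, since the place described for both is the same word for word. Across the compounds shown this change occurs twice. Because the step of a 3.3-fold higher number from compound 1 to compound 2 (0.52 log units; beyond the scatter) was modest but beyond the scatter, compound 4 is expected to give a higher number than compound 3 by a similar amount, estimated as a 3.3-fold higher number from compound 3 to compound 4 (0.51 log units; beyond the scatter). The estimate rests on a single prior example, so it is held loosely. Compound 4 is accordingly estimated at 1700 nM, with a range from 800 nM to 4000 nM.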

Compound 4, half-maximal inhibitory concentration: 980 nM
Compound 4: the middle estimate sits 1.7-fold (0.24 log units) above what was measured; the range from low to high includes it.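

In this assay the same methyl in place of hydrogen on an amine nitrogen gave a 1.9-fold higher number from compound 3 to compound 4 (0.28 log units; within the scatter) on the core of compound 3, so on this core the step cannot be told apart from the scatter of repeated measurements. Set beside the earlier step on the core of compound 1, the two do not differ by more than the scatter allows: the same change on two cores in this assay, a 3.3-fold higher number (0.52 log units; beyond the scatter) from compound 1 to compound 2 and a 1.9-fold higher number (0.28 log units; within the scatter) from compound 3 to compound 4, 1.7-fold (0.24 log units) apart, within the scatter of two such steps. Among the compounds shown here, this fits the change carrying from one core to the other, but it rests on only two pairs of compounds, and it does not show that the step has the same size on both cores or that it has any real effect on the core of compound 3.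

The compounds shown leave open how an ethyl group or a second methyl, as in a dimethylamino group, would read on the same amine nitrogen. They also leave open what a longer chain in place of the aminomethyl group would do on either core.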